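Two Aryl Substituents on a Shared Core, One Swap Ahead

The source may hold more compounds than are shown below. What is called first, only, known or untested is meant among the compounds shown, and "the series" means these compounds.

Compound 1 `CCOc1ccc(-n2cnc3cnc(-c4ccc(F)cc4C)cc32)cc1`: 19 nM
Compound 2 `COc1ccc(-n2cnc3cnc(-c4ccc(F)cc4C)cc32)cc1C(C)C`: > 10000 nM
Compound 3 `Cc1cccc(C)c1-c1cc2c(cn1)ncn2-c1ccc(OC(F)F)cc1`: 980 nM

In a functional assay on HL-60 cells (Homo sapiens) for activation, read by flow cytometry, with a stated time of 4 days (a lower number here means that less compound is needed, a higher number that more compound is needed for the effect), compound 1 gives 19 nM. For compound 2 the result is only a limit of the method, > 10000 nM, not a number (the limit of > 10000 nM in this assay, at which 1 of the 3 values shown sits). Compound 3 gives 980 nM, the higher of the two numbers reported, well beyond the scatter from compound 1.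

Compound 4 `Cc1cc(Cl)ccc1-c1cc2c(cn1)ncn2-c1ccc(OC(F)F)cc1` is not yet measured. It differs from compound 3 in one place (4-chloro-2-methylphenyl in place of 2,6-dimethylphenyl on an aromatic carbon). With this change compound 4 carries a 4-halo-2-methylphenyl group of the same kind as compound 1, whose 19 nM is far lower than that of compound 3. A sizable drop in this assay is therefore expected, as a 16-fold lower number from compound 3 to compound 4 (1.21 log units; beyond the scatter). Compound 4 is estimated at 60 nM, between 15 nM and 250 nM.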

Compound 4, half-maximal effective concentration: 28 nM
Compound 4: the middle estimate sits 2.1-fold (0.33 log units) above what was measured, and the stated range covers the measured number.
By their numbers in this assay, from the lowest: compounds 1 and 4 (each within the scatter of the next); then compound 3. At a limit, above all of these: compound 2.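

Placing 4-chloro-2-methylphenyl instead of 2,6-dimethylphenyl on this aromatic carbon gives a 35-fold lower number from compound 3 to compound 4 (1.54 log units; beyond the scatter) in this assay. This is the only pair shown that differs in one place, so it is the first reading of this position alone, and it shows that the aryl group here can carry a large step by itself. The data shown offer no cause for this step.

The change adds the chlorine and removes a methyl at once, and the compounds shown do not separate the two. As far as these compounds go, how an aryl group carrying an amine or a carboxylic acid in place of the chlorine would read also remains open.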